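Replacing the Amide Substituent on a Shared Core

The source may hold more compounds than are shown below. What is called first, only, known or untested is meant among the compounds shown, and "the series" means these compounds.

Of the compounds shown here, two with a shared core have been measured so far. Compound 1 `COCCNC(=O)Cn1sc2ccccc2c1=O` carries a 2-methoxyethyl group on an amide-type nitrogen, and in an assay on isolated protein for inhibition of histone acetyltransferase KAT2B (Homo sapiens), read by fluorescence, with a stated time of 10 min (on this read-out higher numbers stand for weaker inhibition and lower numbers for stronger inhibition), compound 1 gives 11800 nM. Compound 2 `O=C(Cn1sc2ccccc2c1=O)Nc1nccs1` carries 1,3-thiazol-2-yl at that nitrogen, and in this assay compound 2 gives 9410 nM. The step of a 1.3-fold lower number from compound 1 to compound 2 (0.10 log units; within the scatter) was within the scatter, so on these two numbers compound 2 and compound 1 sit together and neither can be set apart from the other.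

Compound 3 `CC(C)CNC(=O)Cn1sc2ccccc2c1=O` has not yet been measured. It differs from compound 2 by isobutyl in place of 1,3-thiazol-2-yl on an amide-type nitrogen. Within the data shown here, the only measured step bearing on this change is the earlier exchange of one amide substituent for another, a 1.3-fold lower number from compound 1 to compound 2 (0.10 log units; within the scatter), which stayed within the scatter. Compound 3 is therefore expected to show a step of a 1.2-fold higher number from compound 2 to compound 3 (0.07 log units; within the scatter), that is, no shift beyond the scatter. Compound 3 is estimated at 11000 nM, with a range from 5000 nM to 25000 nM.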

Compound 3, half-maximal inhibitory concentration: 10700 nM
Beside the measured number, compound 3's estimate is 1.0-fold (0.01 log units) above it, and the stated range covers the measured number.
By their numbers in this assay, from the lowest: compounds 2, 3 and 1 (each within the scatter of the next).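

With the step of a 1.1-fold higher number from compound 2 to compound 3 (0.06 log units; within the scatter) in this assay, the amide-type nitrogen is shown to carry an open-chain isobutyl with no ring in place of the aromatic 1,3-thiazol-2-yl, without a shift beyond the scatter. The step of a 1.1-fold lower number from compound 1 to compound 3 (0.04 log units; within the scatter), isopropyl in place of methoxymethyl on a saturated chain carbon bound to that nitrogen, also stays within the scatter, so compound 1, compound 2 and compound 3 cannot be set apart. No measurement is available that would explain why these groups read alike.

On these data alone, it remains open whether a carboxylic acid, an amine or a benzyl group on this nitrogen would move the number beyond the scatter. As far as these compounds go, the shared core is the same in all three compounds, so the effect of a change there is also open.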